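A few compounds are considered here, and "the series" means these few. Any claim that something is new, unique, unknown or untested is made for them only; others in the source may bear on it.

Measured so far:
compound 1, `CCCCNc1nnc(SCC(=O)N(Cc2cccc([N+](=O)[O-])c2)c2ccc(F)cc2)s1`, 47.3%
compound 2, `CCCNc1nnc(SCC(=O)N(Cc2cccc([N+](=O)[O-])c2)c2ccc(F)cc2)s1`, 62.3%

In an assay on isolated protein for inhibition of Amine oxidase [flavin-containing] A (Homo sapiens), read by fluorescence and Amplex Red, with a stated time of 30 min, tested at 1 uM (a lower number here means a weaker effect, a higher number a stronger effect of the compound at the concentration tested), compound 2 stands highest of the two numbers shown, and the gap to its only neighbour is beyond the scatter: a number 15 percentage points higher from compound 1 to compound 2 (beyond the scatter).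

Compound 3, `CC(C)CNc1nnc(SCC(=O)N(Cc2cccc([N+](=O)[O-])c2)c2ccc(F)cc2)s1`, has not yet been measured. It differs from compound 2 by methyl in place of hydrogen on a saturated chain carbon bound to two saturated chain carbons. Among the measured compounds shown here, only one measured step bears on this change, the one in which a methyl left the chain and the number rose, and it was modest in size. For compound 3 a methyl enters the chain instead, so the opposite direction, a modest fall, seems more likely than a rise, though the methyl sits at a different place and a single step gives little certainty. The expected step is a number 12.3 percentage points lower from compound 2 to compound 3 (beyond the scatter). For compound 3 the estimate is 50%, with a range from 35% to 65%.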

Compound 3, a percentage reported as inhibition, at one concentration (the size of the read-out at that concentration, not a potency): 43.2%
Compound 3: the middle estimate sits 6.8 percentage points above what was measured; the measured number falls inside the stated range.
By their numbers in this assay, from the lowest: compounds 3 and 1 (each within the scatter of the next); then compound 2.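

In this assay, branching the propylamino chain with a methyl gives a number 19.1 percentage points lower from compound 2 to compound 3 (beyond the scatter), so this carbon of the chain does not accept the added methyl without a loss in the read-out. Compared with the butylamino chain of compound 1, the isobutylamino chain gives a number 4.1 percentage points lower from compound 1 to compound 3 (within the scatter), so among these compounds the straight and branched chains cannot be told apart, and compound 2 stands above both. No measurement here explains why the extra carbon lowers the number.

As far as these compounds go, whether the number would rise further with a shorter ethylamino or methylamino chain remains open. It is also unknown how a cyclopropylamino group, which closes the chain into a ring, would compare with the propylamino chain of compound 2.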